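This account rests on a few compounds, and the source may have more. Where it says the series, first, only, none or still open, it means among the compounds named here.

Within the data shown here, compound 1, `CCCSc1nc(N/N=C(\C)c2ccccc2O)c2nnn(Cc3ccc(Cl)cc3)c2n1`, is the only compound of the pair that gives a number in a functional assay on MGC-803 cells (Homo sapiens) for antiproliferative activity, read by MTT assay, with a stated time of 72 h; on this read-out lower numbers stand for stronger inhibition and higher numbers for weaker inhibition: compound 1 reaches 7100 nM. Compound 2, `CCCSc1nc(N/N=C/c2cccc(Cl)c2)c2nnn(Cc3ccccc3)c2n1`, gives no number in this assay; for compound 2 the value > 64000 nM is a limit rather than a measurement. Compound 1 therefore stands at the only number shown, while the limit of > 64000 nM in this assay, at which 1 of the 2 values shown sits, marks where the remaining value sits. Compound 3, `CCCSc1nc(N/N=C(\C)c2ccccc2O)c2nnn(Cc3ccc(F)cc3)c2n1`, differs from compound 1 in one place: fluoro in place of chloro on an aromatic carbon of a six-membered aromatic ring of carbon only, para to a large group. Among the measured compounds shown here, no step between two measured compounds carries this change, so its size cannot be read from the data. The swap exchanges one halogen for another on the benzyl group, and the expected step from compound 1 to compound 3 is a 1.3-fold higher number from compound 1 to compound 3 (0.13 log units; within the scatter), within the scatter of this assay and leaning, if anything, toward slightly weaker inhibition. Compound 3 is thus expected to give about 9500 nM in this assay, with a range from 4000 nM to 22000 nM.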

Compound 3, half-maximal inhibitory concentration: 11000 nM
Estimate against measurement, compound 3: 1.2-fold (0.06 log units) below; low and high end bracket the measured number.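

In this assay the exchange of chloro for fluoro on an aromatic carbon, para to a large group, can now be read directly as a 1.5-fold higher number from compound 1 to compound 3 (0.19 log units; within the scatter) and so does not separate these two halogens at this place. Compound 3 gives a number just as compound 1 does, which shows that a measurable antiproliferative effect in this series does not depend on chloro in particular, as far as this one exchange goes. Nothing measured here about either halogen bears on this result.

On these data alone, both compounds carry a halogen at this place, so it remains open whether the group there matters at all, and whether a methoxy group, an amine or a carboxylic acid on the same carbon would leave the number within the scatter or move it well beyond. As far as these compounds go, the rest of the molecule is the same in compound 1 and compound 3, so it also remains open how a longer chain in place of the propyl group on sulfur would act alongside either halogen.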